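Aryl swap on the triazole nitrogen: compound 3 to compound 4

The compounds below may be only part of what the source reports. "The series", "measured", "known", "first", "only" and "open" are said of these compounds alone.

Measured so far:
compound 1 `N#CC1=C(N)Oc2c(c3nc4ccccc4nc3c3ccccc23)C12C(=O)N(Cc1cnnn1-c1ccccc1Br)c1ccccc12`: the limit > 50000 nM
compound 2 `N#CC1=C(N)Oc2c(c3nc4ccccc4nc3c3ccccc23)C12C(=O)N(Cc1cnnn1-c1ccc(F)c(Cl)c1)c1ccccc12`: the limit > 50000 nM
compound 3 `Cc1cccc(-n2nncc2CN2C(=O)C3(C(C#N)=C(N)Oc4c(N)cc5nc6ccccc6nc5c43)c3ccccc32)c1`: 12300 nM

Going by the values given here, in a functional assay on A549 cells (Homo sapiens) for antiproliferative activity, read by MTT assay, with a stated time of 48 h (a higher number here means a weaker inhibitor, a lower number a stronger inhibitor), compound 3 holds the only real number of the three; the other two values are limits, and the limit of > 50000 nM in this assay, at which 2 of the 3 values shown sit, marks where they sit. Among the compounds with values here, the one measured pair that changes the aryl group on the aromatic nitrogen is a step that the two limits leave unreadable from compound 1 to compound 2, so its size cannot be read. Compound 4 `N#CC1=C(N)Oc2c(N)cc3nc4ccccc4nc3c2C12C(=O)N(Cc1cnnn1-c1ccc([N+](=O)[O-])cc1)c1ccccc12` differs from compound 3 by 4-nitrophenyl in place of 3-methylphenyl on an aromatic nitrogen. Within the data shown here, no measured step speaks to this change, and the series offers no readable direction for it. Compound 4 is therefore expected near compound 3, with a step of a 1.2-fold higher number from compound 3 to compound 4 (0.09 log units; within the scatter) in this assay, and an estimated value of 15000 nM (range 4000 nM to 50000 nM), with a real chance that only a limit is returned.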

Compound 4, half-maximal inhibitory concentration: > 50000 nM
Compound 4: only a limit was reported; the forecaster's own chance of this, stated with the estimate: 40%; middle value at least 3.3-fold (0.52 log units) from the limit.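

Going by these compounds alone, this is the first readable step at this position: in this assay, 4-nitrophenyl in place of 3-methylphenyl on the aromatic nitrogen gives an at least 4.0-fold higher number from compound 3 to compound 4 (0.60 log units; beyond the scatter). The value of compound 4, > 50000 nM, is a limit. Compound 3 remains the only compound with a real number, and the limit now holds most of the series: the limit of > 50000 nM in this assay, at which 3 of the 4 values shown sit.

Open, on these data alone, is whether a phenyl ring carrying an amine or a carboxylic acid would return a real number in this assay. Also open, as far as these compounds go, is how 3-methylphenyl behaves on the core of compound 1.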